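A few compounds are considered here, and "the series" means these few. Any claim that something is new, unique, unknown or untested is made for them only; others in the source may bear on it.

Compound 1 `NC1=NC2(CCSCC2)N(OCCCOc2ccc(Cl)cc2)C(N)=N1` sits at the higher of the two numbers recorded in a functional assay on HepG2 cells (Homo sapiens) for antiproliferative activity, read by MTT assay, with a stated time of 72 h (on this read-out higher numbers stand for weaker inhibition and lower numbers for stronger inhibition), where compound 1 gives 1100 nM. Within the data shown here, its only neighbour is compound 2 `CC(C)(C)c1ccc(OCCCON2C(N)=NC(N)=NC23CCSCC3)cc1`, which in this assay gives 70 nM, a change of a 16-fold lower number from compound 1 to compound 2 (1.20 log units; beyond the scatter). Compound 3 `NC1=NC2(CCSCC2)N(OCCCOc2ccccc2Cl)C(N)=N1` differs from compound 1 by 2-chlorophenyl in place of 4-chlorophenyl on an oxygen on a saturated carbon. The one measured step exchanges the group itself, not its place on the ring, so nothing shown bears directly on this move. Compound 3 is therefore expected to stay close to compound 1, with a step of about a 1.4-fold higher number from compound 1 to compound 3 (0.13 log units; within the scatter) in this assay. The estimated value for compound 3 is 1500 nM, between 500 nM and 5000 nM.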

Compound 3, half-maximal inhibitory concentration: 80 nM
Compound 3: middle estimate off by 19-fold (1.27 log units), on the high side; the whole stated range lies above it.
By their numbers in this assay, from the lowest: compounds 2 and 3 (each within the scatter of the next); then compound 1.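

The step of a 14-fold lower number from compound 1 to compound 3 (1.14 log units; beyond the scatter) in this assay shows that the same atoms, joined differently, can give a large change: 2-chlorophenyl in place of 4-chlorophenyl matters on its own. Among these compounds, the earlier step showed only that exchanging the group on the ring could matter, whereas this one shows that where the chlorine sits on the ring also counts. No measurement shown here accounts for this difference. Going by these compounds, whether a bromine or a methoxy group in place of that chlorine would behave alike remains open, as does whether a longer chain would preserve the gain.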